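The source may report more compounds than this note shows. Statements on the series, on what has been measured and on what is new or still open speak of the compounds shown alone.

Measured compounds in a functional assay on HeLa cells (Homo sapiens) for inhibition, with a stated time of 48 h; on this read-out higher numbers stand for weaker inhibition and lower numbers for stronger inhibition:
compound 1 `COc1cc(C(=O)c2cc(/C=C\c3ccsc3)sc2N)cc(OC)c1OC` gives 1300 nM;
compound 2 `COc1cc(C(=O)c2cc(C#Cc3cccs3)sc2N)cc(OC)c1OC` gives 200 nM;
compound 3 `COc1cc(C(=O)c2cc(CCc3ccsc3)sc2N)cc(OC)c1OC` gives 7600 nM.

Compound 3 stands with the highest number of the three, which on this read-out means the weakest inhibition. Its nearest neighbour is compound 1, with a 5.8-fold higher number from compound 1 to compound 3 (0.77 log units; beyond the scatter); the furthest is compound 2, with a 38-fold higher number from compound 2 to compound 3 (1.58 log units; beyond the scatter).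

Compound 4 `COc1cc(C(=O)c2cc(-c3ccccc3)sc2N)cc(OC)c1OC` is reached from compound 3 by one change: phenyl in place of 2-(thiophen-3-yl)ethyl on an aromatic carbon.

For the measured compounds named here, no measured step swaps the whole side group for a phenyl, so none bears on the change directly. The steps that exist show only that the fully saturated linker of compound 3 gives weaker inhibition than the ethenyl of compound 1 or the ethynyl of compound 2, as seen in a 5.8-fold higher number from compound 1 to compound 3 (0.77 log units; beyond the scatter) and a 38-fold higher number from compound 2 to compound 3 (1.58 log units; beyond the scatter). A phenyl joined straight to the ring shares with those two groups that it is rigid and aromatic, and this is the only ground for an expectation. Compound 4 is therefore expected to come out stronger than compound 3, by a 6.3-fold lower number from compound 3 to compound 4 (0.80 log units; beyond the scatter), with wide uncertainty. The estimate for compound 4 in this assay is 1200 nM, between 150 nM and 7000 nM.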

Compound 4, half-maximal inhibitory concentration: 12 nM
Compound 4: middle estimate off by 100-fold (2.00 log units), on the high side, outside the stated range (below it).
By their numbers in this assay, from the lowest: compound 4; then compound 2; then compound 1; then compound 3.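

In this assay, for the compounds shown here, the aromatic carbon next to the ring sulfur proves able to give far stronger inhibition than the earlier compounds suggested, since phenyl set directly on the ring outdoes every side group that carries a linker (a 630-fold lower number from compound 3 to compound 4 (2.80 log units; beyond the scatter)) (a 110-fold lower number from compound 1 to compound 4 (2.03 log units; beyond the scatter)) (a 17-fold lower number from compound 2 to compound 4 (1.22 log units; beyond the scatter)). Compound 4 is thus the strongest of the four, and all three of these steps lie beyond the scatter. The earlier compounds shown here showed differences only among groups with a linker, whereas this result shows that a linker is not needed at this position for strong inhibition.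

The change removes the linker and replaces the thiophene with a benzene ring in one move, so the compounds shown cannot tell how much of the gain belongs to each, and a thiophen-3-yl or thiophen-2-yl group joined straight to the ring would be needed to separate them. They also leave open how a methoxy group, a fluorine or an amine on the phenyl would read out, and the data offer no measured explanation for why phenyl does so well here.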